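This account rests on a few compounds, and the source may have more. Where it says the series, first, only, none or still open, it means among the compounds named here.

Measured in a functional assay on A549 cells (Homo sapiens) for inhibition; on this read-out higher numbers stand for weaker inhibition and lower numbers for stronger inhibition:
- compound 1 `Cc1nc2c(s1)C(=O)C=C(Nc1ccc(Br)cc1)C2=O`: 3.6 ug/mL
- compound 2 `Cc1nc2c(s1)C(=O)C=C(Nc1ccc(I)cc1)C2=O`: 2.08 ug/mL

For the measured compounds named here, with compound 2 at 2.08 ug/mL, there is only one measured neighbour to compare it with, and the two values lie within the scatter of each other. Nothing separates them in this assay. The next compound to be tested is compound 3 `Cc1nc2c(s1)C(=O)C=C(Nc1ccc(O)cc1)C2=O`, with hydroxy in place of iodo on an aromatic carbon.

Going by the values given here, only one measured step bears on this change: a 1.7-fold lower number from compound 1 to compound 2 (0.24 log units; within the scatter). That step exchanges bromo for iodo and stays within the scatter, so the read-out did not separate these two groups. Among the compounds with values here, it is weak guidance, however, since no measured compound carries a hydroxy group and the direction cannot be read from the data. A modest move toward a higher number is a tentative expectation, with a small step or none remaining quite possible. The expected size is a 2.2-fold higher number from compound 2 to compound 3 (0.34 log units; beyond the scatter). For compound 3 the estimated value is 4.5 ug/mL, with an expected range from 1.5 ug/mL to 13 ug/mL.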

Compound 3, half-maximal inhibitory concentration: 0.7 ug/mL
Estimate against measurement, compound 3: 6.4-fold (0.81 log units) above, outside the stated range (below it).
By their numbers in this assay, from the lowest: compound 3; then compounds 2 and 1 (each within the scatter of the next).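

In this assay, the bromo and iodo compounds could not be told apart, so the earlier pair gave no sign that the group on this aromatic carbon, para to a large group, mattered at all. Hydroxy changes that picture: replacing iodo gives a 3.0-fold lower number from compound 2 to compound 3 (0.47 log units; beyond the scatter) and replacing bromo gives a 5.1-fold lower number from compound 1 to compound 3 (0.71 log units; beyond the scatter), so both steps are modest but clear of the scatter, and compound 3 is the strongest inhibitor of the three. The position therefore responds to the group it carries, and exchanging either halogen for hydroxy, which adds a hydrogen-bond donor and acceptor that iodo lacks, moves the read-out toward stronger inhibition, but nothing available accounts for this gain.

The compounds shown leave open whether the hydroxy hydrogen itself matters, a question that a methoxy group in the same place would address, and whether an amine there would act as hydroxy does. They also leave open whether moving the hydroxy group to another carbon of this ring would keep the gain, as all three compounds carry their group in the same place.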